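The source may report more compounds than this note shows. Statements on the series, on what has been measured and on what is new or still open speak of the compounds shown alone.

Measured so far in an in vitro ADME assay on microsomes from liver (Mus musculus) for pharmacokinetics, read by LC-MS, with a stated time of 10 min, tested at 1 uM; a higher number here means faster removal of the compound, a lower number slower removal:
- Compound 1 `CN1C[C@H](C(=O)NC2CCCC2)[C@@H](c2ccc(/C=C/C(=O)Nc3ccccc3N)cc2)C1`: 61 mL/min/kg
- Compound 2 `CCN1C[C@H](C(=O)Nc2ccc(Cl)cc2)[C@@H](c2ccc(/C=C/C(=O)Nc3ccccc3N)cc2)C1`: 35 mL/min/kg
- Compound 3 `CC(C)(C)N1C[C@H](C(=O)Nc2ccc(Cl)cc2)[C@@H](c2ccc(/C=C/C(=O)Nc3ccccc3N)cc2)C1`: 20 mL/min/kg

Compound 3 gives 20 mL/min/kg, which lies within the usual scatter of compound 2. Compound 1, at 61 mL/min/kg, lies beyond the scatter from it, on the higher side.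

The next structure is compound 4 `CCNC(=O)N1C[C@H](C(=O)Nc2ccc(Cl)cc2)[C@@H](c2ccc(/C=C/C(=O)Nc3ccccc3N)cc2)C1`, which carries ethylcarbamoyl in place of tert-butyl on an amine nitrogen in a ring.

Going by the values given here, only one measured step touches this nitrogen, a 1.8-fold lower number from compound 2 to compound 3 (0.24 log units; within the scatter). It is small, and it swaps one plain alkyl group for another. Compound 1 differs from compound 3 in more than one place, so it offers no clean comparison. Among the compounds with values here, no measured compound has a carbonyl on this nitrogen, so the data give only weak guidance here, and the range must stay wide.

With so little evidence, a step beyond the scatter is not expected, only a modest drift back toward compound 2 at 35 mL/min/kg. The expected change is a 1.5-fold higher number from compound 3 to compound 4 (0.18 log units; within the scatter). For compound 4 the estimated clearance is 30 mL/min/kg, with an expected range of 13 mL/min/kg to 65 mL/min/kg.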

Compound 4, clearance: 25 mL/min/kg
The estimate for compound 4 lay 1.2-fold (0.08 log units) above the measured number, and the stated range covers the measured number.
By their numbers in this assay, from the lowest: compounds 3, 4, 2 and 1 (each within the scatter of the next, the first and the last beyond it).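

In this assay, this ring nitrogen now carries a group with a carbonyl, which no earlier compound shown had on it. Ethylcarbamoyl in place of tert-butyl gives a 1.3-fold higher number from compound 3 to compound 4 (0.10 log units; within the scatter), and ethylcarbamoyl in place of ethyl gives a 1.4-fold lower number from compound 2 to compound 4 (0.15 log units; within the scatter). Across compounds 2, 3 and 4, then, the nitrogen holds two plain alkyl groups and one group with a hydrogen-bond donor and a hydrogen-bond acceptor, and no step between them leaves the scatter, so this change to the atoms on the nitrogen has no measurable effect on the read-out here, and nothing available explains that result.

As far as these compounds go, whether any group on this nitrogen can move the number beyond the scatter remains open, for example a bare hydrogen, an acetyl group, a sulfonamide, or a longer chain ending in a carboxylic acid or an amine. From the compounds shown here alone, it is also open whether ethylcarbamoyl would behave the same way if the (4-chlorophenyl)carbamoyl group were replaced by the cyclopentyl amide found in compound 1.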